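From isopentylamino to benzylamino in a cytotoxicity test

The source may report more compounds than this note shows. Statements on the series, on what has been measured and on what is new or still open speak of the compounds shown alone.

Of the compounds shown here, two sharing one core have so far been tested in an ADME assay on Vero cells (Chlorocebus sabaeus) for cytotoxicity; a lower number here means that less compound is tolerated, a higher number that more compound is tolerated. Compound 1 `CNc1nc(Nc2ccc(C(C)=O)cc2)c2nc[nH]c2n1` reached only a limit of the assay, > 177000 nM. Going by the values given here, compound 2 `CC(C)CCNc1nc(Nc2cccc(O)c2)c2nc[nH]c2n1` gave a true reading of 151000 nM, the only number available, so its standing cannot be judged against any other measured number.

The next compound to be tested is compound 3 `Oc1cccc(Nc2nc(NCc3ccccc3)nc3[nH]cnc23)c1`, which differs from compound 2 in one place: phenyl in place of isobutyl on a saturated chain carbon bound to a nitrogen on an aromatic ring. The change turns isopentylamino into benzylamino.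

Among the compounds with values here, no measured pair of compounds shows what such a change does in this assay. The expectation therefore stays anchored on compound 2 at 151000 nM. The expected change is a 1.2-fold lower number from compound 2 to compound 3 (0.07 log units; within the scatter), which would lie within the scatter and so implies no firm direction. A reading that ends only as a limit, as it did for compound 1, also remains possible. For compound 3 the estimate is 130000 nM, with an expected range of 60000 nM to 220000 nM.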

Compound 3, half-maximal cytotoxic concentration: > 150000 nM
Compound 3: only a limit was reported; the forecaster's own chance of this, stated with the estimate: 30%; middle value at least 1.1-fold (0.06 log units) from the limit.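

Compound 3 ended only as a limit in this assay, > 150000 nM. Going by these compounds alone, the step from compound 2 to compound 3 therefore cannot be read, and no new step follows from this result. The compounds shown leave open whether benzylamino in place of isopentylamino shifts the reading in this assay at all, and in which direction.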